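The compounds below may be only part of what the source reports. "The series", "measured", "known", "first", "only" and "open" are said of these compounds alone.

Compound 1 `CCCn1c(=O)c2[nH]c(-c3ccc(S(=O)(=O)N4CCN(c5ccc(Cl)cc5)CC4)cc3)nc2n(CC)c1=O` gives 28% in an assay on CHO cells for displacement of a labelled ligand from adenosine receptor A3 (Homo sapiens), read by scintillation counting, with a stated time of 45 min, tested at 1 uM, in the presence of a further agent that is not named here; on this read-out lower numbers stand for less inhibition and higher numbers for more inhibition at the one concentration tested (going by the name of the read-out).
Compound 2 `CCCn1c(=O)c2[nH]c(-c3ccc(S(=O)(=O)N4CCN(c5ccc(Cl)cc5)CC4)cc3)nc2n(C)c1=O` gives 39% in this assay.
Compound 3 `CCCn1c(=O)[nH]c2nc(-c3ccc(S(=O)(=O)N4CCN(c5ccccc5Cl)CC4)cc3)[nH]c2c1=O` gives 32% in this assay.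

Compound 3 holds the second highest of the three numbers. Its nearest neighbour is compound 1, whose number is lower by an amount within the scatter; compound 2 lies furthest away, higher, but that gap too is within the scatter, so none of the three can be set apart from the others on these figures.

The compound not yet measured is compound 4 `CCCn1c(=O)[nH]c2nc(-c3ccc(S(=O)(=O)N4CCN(c5ccccc5F)CC4)cc3)[nH]c2c1=O`. It is derived from compound 3 by the change (fluoro in place of chloro on an aromatic carbon), so that the 2-chlorophenyl of compound 3 becomes a 2-fluorophenyl.

For the measured compounds named here, only one step between measured compounds is available, a number 11 percentage points higher from compound 1 to compound 2 (beyond the scatter), and it concerns a methyl against a hydrogen on a chain carbon bound to an aromatic nitrogen of the shared core; it does not touch the halogen-bearing ring and gives no guide to the present change. Going by the values given here, no measured pair shows a halogen swap. With nothing to push the number in either direction, compound 4 is expected to sit close to compound 3, with a step of a number 2 percentage points lower from compound 3 to compound 4 (within the scatter) that is not expected to exceed the scatter. The estimate for compound 4 in this assay is therefore 30%, within a range from 15% to 45%.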

Compound 4, a percentage reported as inhibition, at one concentration (the size of the read-out at that concentration, not a potency): 9%
Compound 4: the middle estimate sits 21 percentage points above what was measured; the whole stated range lies above it.
By their numbers in this assay, from the lowest: compound 4; then compounds 1, 3 and 2 (each within the scatter of the next, the first and the last beyond it).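

In this assay the halogen on this aromatic carbon, ortho to a large group, turns out to matter: fluoro in place of chloro brings a number 23 percentage points lower from compound 3 to compound 4 (beyond the scatter) and is the first step shown that touches the halogen-bearing ring, since the only earlier step lay on a chain of the shared core. The 2-chlorophenyl and the 2-fluorophenyl therefore cannot be treated as interchangeable here, although the swap exchanges one heavy atom for one heavy atom and neither group brings a hydrogen-bond donor, a hydrogen-bond acceptor or a net charge. This remains the reading of a single pair, and no measurement offered here accounts for the size of the step.

The compounds shown leave open how a bromo, a methyl or a methoxy group on the same aromatic carbon would read, and how the phenyl ring with only a hydrogen there would compare with compound 3 and compound 4. They also leave open whether the same swap of chloro for fluoro would give a similar step on the chlorophenyl ring of compound 1 and compound 2.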